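Removing the methoxyphenyl from the amide nitrogen of compound 2

A few compounds are considered here, and "the series" means these few. Any claim that something is new, unique, unknown or untested is made for them only; others in the source may bear on it.

Of the compounds shown here, three built on a shared fused core have been tested in a functional assay on A549 cells (Homo sapiens) for antiproliferative activity, read by MTT assay, with a stated time of 72 h; on this read-out higher numbers stand for weaker inhibition and lower numbers for stronger inhibition. Compound 1 `COc1ncc(-c2ccc3c(c2)N(c2ccc(C)cc2)C(=O)CO3)cc1NS(=O)(=O)c1ccc(F)cc1` gives 5870 nM in this assay, the only numerical result among the three. Compound 2 `COc1ccc(N2C(=O)COc3ccc(-c4cnc5ccccc5c4)cc32)cc1` is reported at > 40000 nM, which is a limit of the assay and not a number. Compound 3 `O=C1COc2ccc(-c3cccc(NS(=O)(=O)c4ccc(F)cc4)c3)cc2N1c1ccccc1` is reported at > 40000 nM, again a limit only. Going by the values given here, compound 2 thus stands at the limit of > 40000 nM in this assay, at which 2 of the 3 values shown sit, and no measured step connects it to either neighbour, since compound 1 and compound 3 differ from it in more than one place. Compound 4 `O=C1COc2ccc(-c3cnc4ccccc4c3)cc2N1` has not been measured; it differs from compound 2 by hydrogen in place of 4-methoxyphenyl on an amide-type nitrogen in a ring. Among the compounds with values here, no measured pair shows the effect of removing a group from this amide-type nitrogen. Because compound 2 already sits at > 40000 nM, the step of a number no higher from compound 2 to compound 4 (the limit leaves the size open) is expected to be none beyond the scatter, with a further limit the most likely outcome. Compound 4 is therefore estimated at 40000 nM, within a range from 10000 nM to 160000 nM.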

Compound 4, half-maximal inhibitory concentration: > 40000 nM
Compound 4 was reported as a limit; the forecaster's own chance of this, stated with the estimate: 75%; the middle value lies on the limit itself.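

Compound 2 and compound 4 both stand at a limit of the assay and not at a number, so no step between them can be read: the limit of > 40000 nM in this assay, at which 3 of the 4 values shown sit.

The compounds shown leave open whether hydrogen in place of 4-methoxyphenyl on this amide-type nitrogen changes activity at all, in either direction.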